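The source may hold more compounds than are shown below. What is called first, only, known or untested is meant among the compounds shown, and "the series" means these compounds.

Measured compounds:
- compound 1 `CCOc1ccc(-c2cc(=O)c3c(o2)C(CC)(CC)C(=O)C(CC)=C3O)cc1`
- compound 2 `CCC1=C(O)c2c(oc(-c3ccc(C)cc3C)cc2=O)C(CC)(CC)C1=O`, which in a functional assay on KB cells (Homo sapiens) for antiproliferative activity, read by sulforhodamine B assay, with a stated time of 3 days (a higher number here means that more compound is needed for the effect, a lower number that less compound is needed), gives 41.2 uM
- compound 3 `CCC1=C(O)c2c(oc(-c3ccc(OC)c(Cl)c3)cc2=O)C(CC)(CC)C1=O`, which in this assay gives 24.9 uM

In this assay compound 1 gives > 52.4 uM, a limit of the assay and not a number. Compound 1 therefore stands at the limit of > 52.4 uM in this assay, at which 1 of the 3 values shown sits; its own position is known only as a floor. Compound 4 `CCC1=C(O)c2c(oc(-c3ccc(O)c(C)c3C)cc2=O)C(CC)(CC)C1=O` differs from compound 1 in one place: 4-hydroxy-2,3-dimethylphenyl in place of 4-ethoxyphenyl on an aromatic carbon. Two measured steps start from compound 1 and change the same group: an at least 1.2-fold lower number from compound 1 to compound 2 (0.10 log units; that floor lies within the scatter) and an at least 2.1-fold lower number from compound 1 to compound 3 (0.32 log units; beyond the scatter). The second lies beyond the scatter; the first does not. Because of an at least 2.1-fold lower number from compound 1 to compound 3 (0.32 log units; beyond the scatter), a lowering of the number is expected for compound 4, as an at least 1.7-fold lower number from compound 1 to compound 4 (0.24 log units; that floor lies within the scatter). Compound 4 is estimated at 30 uM, with a range from 12 uM to 60 uM.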

Compound 4, concentration for half-maximal effect: 6.5 uM
Estimate against measurement, compound 4: 4.6-fold (0.66 log units) above; measured number below the stated range.
By their numbers in this assay, from the lowest: compound 4; then compounds 3 and 2 (each within the scatter of the next). At a limit, above all of these: compound 1.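

In this assay, the 4-hydroxy-2,3-dimethylphenyl group at this position separates clearly from groups with measured values, which the earlier pair of measured compounds did not do: a 3.8-fold lower number from compound 3 to compound 4 (0.58 log units; beyond the scatter) and a 6.3-fold lower number from compound 2 to compound 4 (0.80 log units; beyond the scatter). This makes compound 4 the lowest of the compounds shown, with steps to all the others beyond the scatter. The third step, an at least 8.0-fold lower number from compound 1 to compound 4 (0.90 log units; beyond the scatter), is only a floor, since compound 1 stands at a limit of the assay: the limit of > 52.4 uM in this assay, at which 1 of the 4 values shown sits.

The compounds shown do not separate the contribution of the hydroxy group from that of the two methyl groups. As far as these compounds go, whether 4-methoxy-2,3-dimethylphenyl or 4-amino-2,3-dimethylphenyl would keep the lower number remains open.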